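4-Fluorophenyl to 4-Fluorobenzyl on the Ring Nitrogen

The source may report more compounds than this note shows. Statements on the series, on what has been measured and on what is new or still open speak of the compounds shown alone.

Three measured compounds share one core and differ mainly in the group carried by an aromatic nitrogen. Compound 1 `CC(C)c1onc(-c2c(Cl)cccc2Cl)c1COc1ccc(-c2nc3cc(C(=O)O)ccc3n2C)cc1` gives 4410 nM in an assay on HEK-293T cells for antagonist activity at vitamin D3 receptor (Homo sapiens), read by a luciferase reporter, with a stated time of 24 h; a lower number here means a stronger inhibitor, a higher number a weaker inhibitor. Compound 2 `CC(C)c1onc(-c2c(Cl)cccc2Cl)c1COc1ccc(-c2nc3ccc(C(=O)O)cc3n2-c2ccc(F)cc2)cc1` gives 2410 nM in this assay. Compound 3 `CCC(CC)n1c(-c2ccc(OCc3c(-c4c(Cl)cccc4Cl)noc3C(C)C)cc2Cl)nc2ccc(C(=O)O)cc21` gives 1010 nM in this assay. Among these three numbers compound 2 holds the second highest; its gap to compound 1 lies within the usual scatter, while compound 3 sits beyond the scatter with a lower number. Compound 4 `CC(C)c1onc(-c2c(Cl)cccc2Cl)c1COc1ccc(-c2nc3ccc(C(=O)O)cc3n2Cc2ccc(F)cc2)cc1` carries 4-fluorobenzyl in place of 4-fluorophenyl on an aromatic nitrogen. Among the compounds with values here, no measured pair shows this exact change, so the expectation rests on the spread above. A small shift toward a lower number is expected, a 1.3-fold lower number from compound 2 to compound 4 (0.13 log units; within the scatter), with wide uncertainty in both directions. Compound 4 is therefore estimated at 1800 nM, within 700 nM to 4500 nM.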

Compound 4, half-maximal inhibitory concentration: 1140 nM
Compound 4: middle estimate off by 1.6-fold (0.20 log units), on the high side; low and high end bracket the measured number.
By their numbers in this assay, from the lowest: compounds 3 and 4 (each within the scatter of the next); then compounds 2 and 1 (each within the scatter of the next).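

Swapping 4-fluorophenyl for 4-fluorobenzyl on the aromatic nitrogen gives a 2.1-fold lower number from compound 2 to compound 4 (0.33 log units; beyond the scatter) in this assay and so moves the number by a modest amount. Within the data shown here, this is the first change confined to this one position, and it shows that the number responds to the group on this nitrogen even with the fluorinated ring kept. No measurement here explains this shift.

Still open, on these data alone, is whether a longer chain, such as 2-(4-fluorophenyl)ethyl, would lower the number further or raise it. As far as these compounds go, whether plain benzyl, without the fluorine, would behave like 4-fluorobenzyl also remains unknown.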